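Methyl for Fluoro: What to Expect of Compound 4

A few compounds are considered here, and "the series" means these few. Any claim that something is new, unique, unknown or untested is made for them only; others in the source may bear on it.

Of the compounds shown here, three built on one shared core have been measured in a functional assay on HCT-116 cells (Homo sapiens) for cytotoxicity, read by MTT assay, with a stated time of 48 h; a lower number here means a stronger inhibitor, a higher number a weaker inhibitor. Compound 1 `O=C(/C=C/c1ccc2c(c1)B(O)OC2)c1ccc(-c2ccccc2)cc1` gives 9500 nM, compound 2 `O=C(/C=C/c1ccc2c(c1)B(O)OC2)c1cccnc1` gives 20500 nM, and compound 3 `O=C(/C=C/c1ccc2c(c1)B(O)OC2)c1ccc(F)cc1` gives 2800 nM. Compound 3 therefore stands lowest of the three numbers: the step of a 3.4-fold lower number from compound 1 to compound 3 (0.53 log units; beyond the scatter) and the step of a 7.3-fold lower number from compound 2 to compound 3 (0.86 log units; beyond the scatter) are both beyond the scatter, so compound 3 is the strongest inhibitor among the measured set.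

Compound 4 `Cc1ccc(C(=O)/C=C/c2ccc3c(c2)B(O)OC3)cc1` differs from compound 3 by methyl in place of fluoro on an aromatic carbon. Going by the values given here, no measured step exchanges methyl for fluoro, so the guidance is indirect. The step of a 3.4-fold lower number from compound 1 to compound 3 (0.53 log units; beyond the scatter) shows that fluoro on that aromatic carbon gave a lower number than phenyl there, and the step of a 7.3-fold lower number from compound 2 to compound 3 (0.86 log units; beyond the scatter) shows the 4-fluorophenyl ketone ahead of the pyridin-3-yl ketone; neither compares two groups of one heavy atom each. With one single-atom group replacing another at the same place, the expected step of a 1.4-fold higher number from compound 3 to compound 4 (0.15 log units; within the scatter) in this assay is small, most likely within the scatter, with a slight lean toward a higher number. Compound 4 is accordingly estimated at 4000 nM, with a range from 1500 nM to 11000 nM.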

Compound 4, half-maximal inhibitory concentration: 10500 nM
The estimate for compound 4 lay 2.6-fold (0.42 log units) below the measured number; the range from low to high includes it.
By their numbers in this assay, from the lowest: compound 3; then compounds 1, 4 and 2 (each within the scatter of the next, the first and the last beyond it).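

In this assay, methyl in place of fluoro on an aromatic carbon para to a large group is not a neutral exchange, although each group counts one heavy atom and neither counts a hydrogen-bond donor or acceptor: the result is a 3.8-fold higher number from compound 3 to compound 4 (0.57 log units; beyond the scatter). With methyl at this place, compound 4 no longer stands apart from the other two compounds, as shown by a 1.1-fold higher number from compound 1 to compound 4 (0.04 log units; within the scatter) and a 2.0-fold lower number from compound 2 to compound 4 (0.29 log units; within the scatter), so among the four compounds only compound 3, with its 4-fluorophenyl group, has a number separated beyond the scatter from all the others. Nothing available here accounts for the difference between fluoro and methyl at this place.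

The compounds shown leave open whether the lower number of compound 3 is particular to fluoro or would also be seen with chloro, methoxy or a hydroxyl group at the same place, or with an unsubstituted phenyl ring. They also leave open whether the step from fluoro to methyl would be of similar size on a core other than the shared one.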